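The compounds below may be only part of what the source reports. "The series", "measured", "known", "first", "only" and "open" are said of these compounds alone.

Measured in a functional assay on PANC-1 cells (Homo sapiens) for inhibition, read by MTT assay, with a stated time of 24 h, tested at 10 uM; on this read-out lower numbers stand for less inhibition and higher numbers for more inhibition at the one concentration tested (going by the name of the read-out):

compound 1 `CC(C)=CCOc1cc(=O)n(CCCO)c2c1CC(CC=C(C)C)C(C)(C)C2` gives 7.5%
compound 2 `CC(C)=CCC1Cc2c(OC(=O)Nc3ccc(F)c(F)c3)cc(=O)n(CCCO)c2CC1(C)C` gives 0%
compound 3 `CC(C)=CCC/C(C)=C/CC1Cc2c(OCC=C(C)C)cc(=O)n(CCCO)c2CC1(C)C` gives 15.9%

Compound 3 holds the highest of the three numbers; its nearest neighbour is compound 1, within the scatter, while compound 2 lies beyond the scatter below it.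

Compound 4 `COc1ccccc1NC(=O)Oc1cc(=O)n(CCCO)c2c1CC(C/C=C(\C)CCC=C(C)C)C(C)(C)C2` differs from compound 3 in one place: (2-methoxyphenyl)carbamoyl in place of 3-methylbut-2-en-1-yl on an oxygen on an aromatic ring. Within the data shown here, the only measured step that bears on this is the one from compound 1 to compound 2, where a carbamoyl group likewise replaced 3-methylbut-2-en-1-yl on the aromatic oxygen: a number 7.5 percentage points lower from compound 1 to compound 2 (within the scatter). On that basis the expected step is a number 6.9 percentage points lower from compound 3 to compound 4 (within the scatter), a small lowering that need not exceed the scatter. Compound 4 is therefore estimated at 9%, with a range from 0% to 22%.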

Compound 4, a percentage reported as inhibition, at one concentration (the size of the read-out at that concentration, not a potency): 0%
Beside the measured number, compound 4's estimate is 9 percentage points above it, within the range that was stated.
By their numbers in this assay, from the lowest: compounds 2, 4, 1 and 3 (each within the scatter of the next, the first and the last beyond it).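

On the oxygen on the aromatic ring, (2-methoxyphenyl)carbamoyl in place of 3-methylbut-2-en-1-yl gives a number 15.9 percentage points lower from compound 3 to compound 4 (beyond the scatter) in this assay. Among these compounds, this is the first carbamoyl change to clear the scatter, whereas the earlier change gave a number 7.5 percentage points lower from compound 1 to compound 2 (within the scatter) on the core of compound 1. Nothing on hand explains this step.

The compounds shown leave open whether the carbamoyl link or its aromatic ring carries the step. They also leave open how a carboxylic acid or an amine on the group at this oxygen would read out.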